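This account rests on a few compounds, and the source may have more. Where it says the series, first, only, none or still open, it means among the compounds named here.

Compound 1 `C=C1CC[C@@H]2[C@](C)(CO)[C@H](O)CC[C@@]2(C)[C@@H]1CC(Sc1ccccc1)C1=CCOC1=O` — 14000 nM
Compound 2 `C=C1CC[C@@H]2[C@](C)(CO)[C@H](O)CC[C@@]2(C)[C@@H]1CC(Sc1ccc(F)cc1)C1=CCOC1=O` — 16000 nM
Compound 3 `C=C1CC[C@@H]2[C@](C)(CO)[C@H](O)CC[C@@]2(C)[C@@H]1CC(Sc1ccc(OC)cc1)C1=CCOC1=O` — 15000 nM

The three measured compounds share one core and differ only in the ring carried on the sulfur. In a functional assay on PC-3 cells (Homo sapiens) for inhibition, read by MTT assay, with a stated time of 48 h (a lower number here means a stronger inhibitor, a higher number a weaker inhibitor), compound 1 gives 14000 nM, compound 2 gives 16000 nM and compound 3 gives 15000 nM. Compound 3 sits between the other two, but all three numbers lie within the scatter of one another: the steps of a 1.1-fold higher number from compound 1 to compound 2 (0.06 log units; within the scatter), a 1.1-fold higher number from compound 1 to compound 3 (0.03 log units; within the scatter) and a 1.1-fold lower number from compound 2 to compound 3 (0.03 log units; within the scatter) are each too small to count as real change.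

Compound 4 `C=C1CC[C@@H]2[C@](C)(CO)[C@H](O)CC[C@@]2(C)[C@@H]1CC(Sc1nccs1)C1=CCOC1=O` carries 1,3-thiazol-2-yl in place of 4-methoxyphenyl on a sulfur. Among the compounds with values here, none of the measured steps swaps the aromatic ring itself; they only vary a substituent on it, and each of those swaps left this assay unmoved. That gives no reason to expect a move in either direction, though the untested ring leaves room for surprise. Compound 4 is therefore expected to land near compound 3, the estimated step being a 1.2-fold lower number from compound 3 to compound 4 (0.06 log units; within the scatter). The estimate for compound 4 is 13000 nM, with a range from 5000 nM to 35000 nM.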

Compound 4, half-maximal inhibitory concentration: 14000 nM
The estimate for compound 4 lay 1.1-fold (0.03 log units) below the measured number; measured number inside the range.
By their numbers in this assay, from the lowest: compounds 1, 4, 3 and 2 (each within the scatter of the next).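

The earlier compounds shown here only varied a substituent on a phenyl ring, whereas this change replaces the whole ring on the sulfur, and this assay still shows no real shift (a 1.1-fold lower number from compound 3 to compound 4 (0.03 log units; within the scatter); a 1.1-fold lower number from compound 2 to compound 4 (0.06 log units; within the scatter); no change at the digits printed from compound 1 to compound 4 (within the scatter)). All three steps lie within the scatter, so on this sulfur a five-membered aromatic ring with 2 hetero atoms reads the same as the six-membered rings of carbon only. Nothing measured here explains this flat response.

Going by these compounds, all four compounds carry an aromatic ring on the sulfur, so it remains open whether a non-aromatic group there, such as a carboxylic acid or an aminoethyl chain, would move the number. Changes to the shared core also remain open, since it is identical throughout.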